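The source may report more compounds than this note shows. Statements on the series, on what has been measured and on what is new or still open speak of the compounds shown alone.

Four related compounds share one core, a carboxylic acid head joined through a chain of rings to an alkoxy-bearing outer ring. Compound 1 `Cc1cc(OCC(C)C)cc(C)c1-c1cccc(COc2ccc(OCC(=O)O)c(F)c2)c1` and compound 2 `CCCCOc1cc(C)c(-c2cccc(COc3ccc(OCC(=O)O)c(F)c3)c2)c(C)c1` were tested in a functional assay on CHO cells for agonist activity at Free fatty acid receptor 1 (Homo sapiens), read by FLIPR and calcium flux (a higher number here means that more compound is needed for the effect, a lower number that less compound is needed), but for compound 1 the outcome is "not determined" (no result reported) and for compound 2 it is likewise "not determined" (no result reported). Among the measured compounds shown here, that leaves compound 3 `CCCOc1cc(C)c(-c2cccc(COc3ccc(OCC(=O)O)c(F)c3)c2)c(C)c1` as the only member with a number: in this assay compound 3 gives 106 nM, so it stands alone and cannot be ranked against the others.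

Compound 4 `COCCOc1cc(C)c(-c2cccc(COc3ccc(OCC(=O)O)c(F)c3)c2)c(C)c1` differs from compound 3 in one place: methoxy in place of methyl on a saturated chain carbon, two bonds along the chain from an oxygen on an aromatic ring, so the propoxy group becomes a 2-methoxyethoxy group. For the measured compounds named here, no measured pair shows what such a swap does here. Going by the values given here, with only one number to lean on, the expectation is a step in this assay from compound 3 to compound 4 of about a 1.7-fold higher number from compound 3 to compound 4 (0.23 log units; within the scatter), a shift that may well stay within the ordinary scatter. Compound 4 is therefore estimated at 180 nM, within a range from 60 nM to 600 nM.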

Compound 4, half-maximal effective concentration in the Free fatty acid receptor 1 assay: 104 nM
The estimate for compound 4 lay 1.7-fold (0.24 log units) above the measured number; the range from low to high includes it.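

In the Free fatty acid receptor 1 assay, placing methoxy where methyl stood, on a saturated chain carbon two bonds along the chain from an oxygen on an aromatic ring, gives a 1.0-fold lower number from compound 3 to compound 4 (0.01 log units; within the scatter). The earlier compounds shown here offered no pair, and this first one shows that the propoxy group can become a 2-methoxyethoxy group with no readable shift in the number for the receptor. In a physicochemical assay for lipophilicity, using the shake flask method, in phosphate buffer, measured as octanol-water partition, with a stated time of 24 h, at pH 7.4, tested at 100 uM (a lower number here means a more polar compound, a higher number a more lipophilic compound), compound 3 gives 3.64 and compound 4 gives 3.15. Measured in the physicochemical assay, the same swap does leave a mark, giving a more polar compound while the receptor number holds: the measured distribution coefficient of compound 3, 3.64, and of compound 4, 3.15, a number 0.49 log units lower (beyond the scatter)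

This is a single pair on one core, so it sets no general rule for the position. Going by these compounds, how a chain ending in an amine, a hydroxyl or a carboxylic acid would read at this place stays open, as does a longer chain with its oxygen further out.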